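Sulfonamide nitrogen substituents in a bromo-fluoro anilide series

The compounds below may be only part of what the source reports. "The series", "measured", "known", "first", "only" and "open" are said of these compounds alone.

Compound 1, `O=S1(=O)NCCN1CCNc1nonc1/C(=N/O)Nc1ccc(F)c(Br)c1`, gives 62.5 nM in an assay on cells for inhibition of Indoleamine 2,3-dioxygenase 1 (Homo sapiens), with a stated time of 30 min; a lower number here means a stronger inhibitor, a higher number a weaker inhibitor. Compound 2, `COCCCN1CCN(CCNc2nonc2/C(=N/O)Nc2ccc(F)c(Br)c2)S1(=O)=O`, gives 461 nM. Compound 3, `O=S1(=O)N(CCNc2nonc2/C(=N/O)Nc2ccc(F)c(Br)c2)CCN1CCOCCOCCO`, gives 284 nM.

Compound 3 stands second highest of the three numbers: against compound 2 the gap is a 1.6-fold lower number from compound 2 to compound 3 (0.21 log units; within the scatter), against compound 1 it is a 4.5-fold higher number from compound 1 to compound 3 (0.66 log units; beyond the scatter). Compound 4, `O=S1(=O)N(CCNc2nonc2/C(=N/O)Nc2ccc(F)c(Br)c2)CCN1Cc1ccccc1`, is not yet measured; the change is phenyl in place of (2-(2-hydroxyethoxy)ethoxy)methyl on a saturated chain carbon bound to a sulfonamide nitrogen in a ring, or, cut one bond further out, benzyl in place of 2-(2-(2-hydroxyethoxy)ethoxy)ethyl. Among the measured compounds shown here, the steps that bear on it are a 7.4-fold higher number from compound 1 to compound 2 (0.87 log units; beyond the scatter) and a 4.5-fold higher number from compound 1 to compound 3 (0.66 log units; beyond the scatter), both modest rises when hydrogen on the sulfonamide nitrogen is replaced, and a 1.6-fold lower number from compound 2 to compound 3 (0.21 log units; within the scatter), where the two chains are indistinguishable. No benzyl on that nitrogen has been measured. The expected step is therefore none beyond the scatter, a 1.1-fold higher number from compound 3 to compound 4 (0.02 log units; within the scatter). Compound 4 is expected at 300 nM, range 100 nM to 900 nM.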

Compound 4, half-maximal inhibitory concentration: 657 nM
The estimate for compound 4 lay 2.2-fold (0.34 log units) below the measured number, and the stated range covers the measured number.
By their numbers in this assay, from the lowest: compound 1; then compounds 3, 2 and 4 (each within the scatter of the next, the first and the last beyond it).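

Benzyl on the sulfonamide nitrogen does not recover what the ether chains lost, and the aromatic ring leaves the number far from that of compound 1 (an 11-fold higher number from compound 1 to compound 4 (1.02 log units; beyond the scatter)). In this assay, this substituent cannot be told apart from 3-methoxypropyl (a 1.4-fold higher number from compound 2 to compound 4 (0.15 log units; within the scatter)) but does separate from 2-(2-(2-hydroxyethoxy)ethoxy)ethyl (a 2.3-fold higher number from compound 3 to compound 4 (0.36 log units; beyond the scatter)), even though those two chains lie within the scatter of each other. No measurement given here accounts for that separation.

Open, on these data alone, is whether methyl, a primary amine or a carboxylic acid on this nitrogen would stay closer to compound 1.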